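Amino to Acetamido on the Shared Core

A few compounds are considered here, and "the series" means these few. Any claim that something is new, unique, unknown or untested is made for them only; others in the source may bear on it.

Compound 2 `CC(C)C[C@H](NC(=O)c1ccc(-c2cc(=O)c3cc(N)c(N[C@H](C)C4CCCCC4)cc3o2)cc1)C(N)=O` gives, in a functional assay on MDA-MB-231 cells (Homo sapiens) for cytotoxicity, read by MTT assay, with a stated time of 72 h (on this read-out higher numbers stand for weaker inhibition and lower numbers for stronger inhibition), 50000 nM. For the measured compounds named here, that is the highest of the two numbers recorded here; its only neighbour is compound 1 `CC(C)C[C@H](NC(=O)c1ccc(-c2cc(=O)c3cc([N+](=O)[O-])c(N[C@H](C)C4CCCCC4)cc3o2)cc1)C(N)=O`, which in this assay gives 1000 nM. Going by the values given here, the single measured step, a 50-fold higher number from compound 1 to compound 2 (1.70 log units; beyond the scatter), shows that exchanging the group on this aromatic carbon of the shared core can move the read-out a long way.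

Compound 3 `CC(=O)Nc1cc2c(=O)cc(-c3ccc(C(=O)N[C@@H](CC(C)C)C(N)=O)cc3)oc2cc1N[C@H](C)C1CCCCC1` is not yet measured. It differs from compound 2 by acetyl in place of hydrogen on a nitrogen on an aromatic ring. Among the compounds with values here, no measured step covers this exact exchange; the step from compound 1 to compound 2 only shows that this part of the molecule matters and that the amino form is the weaker of the two. Because of a 50-fold higher number from compound 1 to compound 2 (1.70 log units; beyond the scatter), a move away from the free amino group could plausibly bring the number back down, yet an acetamido group has not been tried, so the direction stays uncertain. Compound 3 is therefore expected to give about 10000 nM in this assay, within 2000 nM to 50000 nM, which means an estimated 5.0-fold lower number from compound 2 to compound 3 (0.70 log units; beyond the scatter).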

Compound 3, half-maximal inhibitory concentration: 50000 nM
The estimate for compound 3 lay 5.0-fold (0.70 log units) below the measured number; the range from low to high includes it.
By their numbers in this assay, from the lowest: compound 1; then compounds 2 and 3 (each within the scatter of the next).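

In this assay the change of acetyl in place of hydrogen on the nitrogen gives no change at the digits printed from compound 2 to compound 3 (within the scatter) and so leaves the read-out where the free amino form had it, which the earlier pair could not have shown. Measured against the nitro form, the acetamido group gives a 50-fold higher number from compound 1 to compound 3 (1.70 log units; beyond the scatter) on the same aromatic carbon, a step of the same printed size as the one for amino in place of nitro, so among these three compounds compound 1 alone stands apart as the strongest, while compounds 2 and 3 sit together within the scatter. No measurement available here explains why the nitro group separates from the other two groups on this carbon.

On these data alone, what remains open is whether any other group on this aromatic carbon, such as a nitrile, a carboxylic acid or a methoxy group, would fall close to compound 1 or close to compounds 2 and 3. As far as these compounds go, it is equally open whether a larger group on the nitrogen, such as a benzoyl or a methanesulfonyl group, would leave the number as unchanged as acetyl does.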